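This account rests on a few compounds, and the source may have more. Where it says the series, first, only, none or still open, it means among the compounds named here.

Measured in an ADME assay for permeability, using PAMPA, with a stated time of 4 h, at pH 7.4; a lower number here means that the compound crosses the layer more slowly, a higher number that the compound crosses the layer faster:
- compound 1 `NCCCCN(C[C@H]1Cc2ncccc2CN1)[C@H]1CCCc2cccnc21`: 14 nm/s
- compound 2 `CN(C[C@H]1Cc2ncccc2CN1)[C@H]1CCCc2cccnc21`: 1300 nm/s
- compound 3 `NC(=O)NCCCCN(C[C@H]1Cc2ncccc2CN1)[C@H]1CCCc2cccnc21`: 2 nm/s

In this assay, compound 3 has the lowest number of the three, at 2 nm/s. It lies a 7.0-fold lower number from compound 1 to compound 3 (0.85 log units; beyond the scatter) and a 650-fold lower number from compound 2 to compound 3 (2.81 log units; beyond the scatter).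

Compound 4 `NC(=O)NC/C=C\CN(C[C@H]1Cc2ncccc2CN1)[C@H]1CCCc2cccnc21` is the next compound to read. Its change is a group of 7 heavy atoms (4 carbon, 2 nitrogen, 1 oxygen; no ring) in place of a group of 7 heavy atoms (4 carbon, 2 nitrogen, 1 oxygen; no ring), on a saturated chain carbon bound to an amine nitrogen. The 3-ureidopropyl group leaves, and a group with no common name enters in the same place, on a saturated chain carbon bound to an amine nitrogen.

Two measured steps also change the substituent at this place, and both are large: a 93-fold higher number from compound 1 to compound 2 (1.97 log units; beyond the scatter) and a 650-fold lower number from compound 2 to compound 3 (2.81 log units; beyond the scatter). The modest step of a 7.0-fold lower number from compound 1 to compound 3 (0.85 log units; beyond the scatter) adds carbamoyl on an amine nitrogen. Each of these steps adds or removes atoms, whereas the change to compound 4 keeps the heavy-atom make-up the same. Among the measured compounds shown here, no measured pair isolates a change of this kind, so its direction is not established by the data. A small step is expected rather than one of the size seen in those three.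

The expected step is a 1.5-fold higher number from compound 3 to compound 4 (0.18 log units; within the scatter), which is not expected to exceed the scatter. For compound 4 the estimated value is 3 nm/s, with an expected range of 1 nm/s to 10 nm/s.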

Compound 4, apparent permeability: 2 nm/s
Estimate against measurement, compound 4: 1.5-fold (0.18 log units) above, within the range that was stated.
By their numbers in this assay, from the lowest: compounds 3 and 4 (each within the scatter of the next); then compound 1; then compound 2.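

In this assay, putting the group with the added chain double bond in place of 3-ureidopropyl, with the same heavy-atom make-up and the same donor and acceptor counts, gives no change at the digits printed from compound 3 to compound 4 (within the scatter) at this saturated chain carbon bound to an amine nitrogen. The other two comparisons keep the sizes seen for compound 3, with a 650-fold lower number from compound 2 to compound 4 (2.81 log units; beyond the scatter) and a 7.0-fold lower number from compound 1 to compound 4 (0.85 log units; beyond the scatter) on the same side of the series, so among the compounds shown the added double bond does not separate the two chains carrying the carbamoyl end. The data on hand hold nothing that accounts for this flat step.

Still open, as far as these compounds go, is whether this flat reading extends to other unsaturated chains, such as the opposite geometry about the double bond or a chain with a triple bond at the same place. Also open, from the compounds shown here alone, is how far this assay moves with a chain ending in a carboxylic acid or a hydroxyl, or with a longer chain, set against compound 1 and compound 2 at this same place.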